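Amide-side amine swap in a fused seven-membered series

The source may hold more compounds than are shown below. What is called first, only, known or untested is meant among the compounds shown, and "the series" means these compounds.

Measured compounds:
compound 1 `Cc1ccc(C2=CCc3ccccc3N=C2N2CCN(C)CC2)cc1` — 31%
compound 2 `Brc1ccc2c(c1)CC=C(c1ccccc1)C(N1CCNCC1)=N2` — 31%

Two compounds have been run so far in a functional assay on the whole organism for inhibition, with Mus musculus as the target, at a dose of 100 mg/kg by the oral route; on this read-out lower numbers stand for less inhibition and higher numbers for more inhibition at the one dose given (going by the name of the read-out). Compound 1 gives 31% in this assay. Compound 2 gives 31% in this assay, which leaves it level with compound 1 at the digits read, the gap lying within the scatter of repeat runs. For the measured compounds named here, the two compounds differ in more than one place, so their values are taken only as a pair of read-outs and no step is drawn between them.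

Compound 3 `Brc1ccc2c(c1)CC=C(c1ccccc1)C(N1CCCCC1)=N2` is not yet measured. It differs from compound 2 in one place: piperidin-1-yl in place of piperazin-1-yl on a carbon with a double bond to nitrogen. The ring that leaves carries a donor; the ring that enters carries none, the place being the carbon with a double bond to nitrogen of the seven-membered non-aromatic ring.

Going by the values given here, no single-change step is available in this assay to scale such a swap. The step of a number 3 percentage points lower from compound 2 to compound 3 (within the scatter) is expected to be small, with no direction beyond the scatter. For compound 3 the estimate in this assay is 28%, with a range from 10% to 50%.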

Compound 3, a percentage reported as inhibition, in the whole organism at one dose (the size of the read-out at that dose, not a potency): 31%
Compound 3: the middle estimate sits 3 percentage points below what was measured, within the range that was stated.
By their numbers in this assay, from the lowest: compounds 1, 2 and 3 (each within the scatter of the next).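

In this assay, for the compounds shown here, piperidin-1-yl in place of piperazin-1-yl on a carbon with a double bond to nitrogen gives no change at the digits printed from compound 2 to compound 3 (within the scatter), the only single-change step so far and the first direct reading at this place. The ring that enters lacks both the second ring nitrogen and the hydrogen-bond donor of the ring that leaves, so at this one oral dose neither feature is needed to hold the read-out of this pair within the scatter. No measurement at hand bears on why the read-out holds across this swap, and the step says nothing about potency, since the read-out is the size of the inhibition at a single dose.

Still open, as far as these compounds go, is whether morpholin-4-yl, or an open-chain amine such as dimethylamino, on the same carbon would also stay within the scatter of compound 3 in this assay. Also open, from the compounds shown here alone, is how a smaller group than bromine on the shared core, or a substituent on the phenyl group, would read with the piperidin-1-yl ring in place.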